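Cyclohexyl in place of chloro: expected cytotoxicity of compound 3

A few compounds are considered here, and "the series" means these few. Any claim that something is new, unique, unknown or untested is made for them only; others in the source may bear on it.

Compound 1, `NC(=S)Nc1cccc(OCCCCCN2CCN(c3ccc(Cl)cc3)C2=S)c1`: in an ADME assay on Huh-7 cells (Homo sapiens) for cytotoxicity (on this read-out higher numbers stand for lower toxicity in this test and lower numbers for higher toxicity in this test), compound 1 reaches only the assay limit > 50000 nM.
Compound 2, `NC(=S)Nc1cccc(OCCCCCN2CCN(c3ccc(Cl)c(Cl)c3)C2=S)c1`: in this assay compound 2 likewise reaches only the assay limit > 50000 nM.

Compound 1 therefore stands at the limit, not at a measured number, and the same holds for compound 2 (the limit of > 50000 nM in this assay, at which 2 of the 2 values shown sit). Among the measured compounds shown here, the one measured step, a step that the two limits leave unreadable from compound 1 to compound 2, is unreadable, since both of its ends are limits.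

Compound 3, `NC(=S)Nc1cccc(OCCCCCN2CCN(c3ccc(C4CCCCC4)cc3)C2=S)c1`, differs from compound 1 by cyclohexyl in place of chloro on an aromatic carbon. For the measured compounds named here, no measured step touches that change, and the only step at hand gives no readable size. The expectation for compound 3 thus rests on both measured compounds sitting at the limit: compound 3 is expected to give 50000 nM, with a range from 15000 nM to 100000 nM. The estimated step of a number no higher from compound 1 to compound 3 (the limit leaves the size open) is expected to be none beyond the scatter, most likely ending again at the limit.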

Compound 3, half-maximal cytotoxic concentration: > 50000 nM
Compound 3 was reported as a limit (the forecaster's own chance of this, stated with the estimate: 70%); the middle value lies on the limit itself.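

Compound 1 and compound 3 both end at a limit rather than a measured number, so the step between them cannot be read in this assay: the limit of > 50000 nM in this assay, at which 3 of the 3 values shown sit.

The compounds shown leave open how far each lies past that limit, and whether swapping chloro for cyclohexyl changes cytotoxicity at all.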